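The source may hold more compounds than are shown below. What is called first, only, known or untested is meant among the compounds shown, and "the series" means these compounds.

Compound 1, `CC(C)(C)OC(=O)NCCCCNCCCN(Cc1ccc(-c2ccccc2)cc1)Cc1ccc(-c2ccccc2)cc1`, was examined in an ADME assay on RAW264.7 cells (Mus musculus) for cytotoxicity, read by resazurin assay, with a stated time of 48 h; a higher number here means that more compound is tolerated, a lower number that less compound is tolerated. In this assay compound 1 reports > 100000 nM, which is a limit of the assay rather than a number, and this reading sits at the limit of > 100000 nM in this assay, at which 1 of the 3 values shown sits. Compound 3, `NCCCCNCCCN(Cc1ccc(-c2ccccc2)cc1)Cc1ccc(-c2ccccc2)cc1`, gives 4200 nM in this assay. The two differ by hydrogen in place of tert-butoxycarbonyl on an amine nitrogen, and that change made an at least 23-fold lower number from compound 1 to compound 3 (1.37 log units; beyond the scatter). Compound 2, `CC(C)(C)OC(=O)NCCCCNCCCN(Cc1ccc2ccccc2c1)Cc1ccc2ccccc2c1`, gives 4300 nM in this assay, a value that lies within the usual scatter of that of compound 3. How the core of compound 2 differs from that of compound 1 is not broken down here. For the measured compounds named here, compound 4, `NCCCCNCCCN(Cc1ccc2ccccc2c1)Cc1ccc2ccccc2c1`, remains to be measured; it differs from compound 2 by hydrogen in place of tert-butoxycarbonyl on an amine nitrogen, the same change, at the same place, as the one separating compound 3 from compound 1. For compound 4 the step expected in this assay is a 4.3-fold lower number from compound 2 to compound 4 (0.63 log units; beyond the scatter), smaller than the earlier one because an at least 23-fold lower number from compound 1 to compound 3 (1.37 log units; beyond the scatter) starts from a limit and so marks only the floor of the true drop. Compound 4 is therefore estimated at 1000 nM, between 200 nM and 4000 nM.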

Compound 4, half-maximal cytotoxic concentration: 4900 nM
Beside the measured number, compound 4's estimate is 4.9-fold (0.69 log units) below it; the measured number lies above the stated range.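

On the core of compound 2, hydrogen in place of tert-butoxycarbonyl on an amine nitrogen gave a 1.1-fold higher number from compound 2 to compound 4 (0.06 log units; within the scatter) in this assay, so the change did not carry over with the size it had on the core of compound 1: the same change on two cores in this assay, an at least 23-fold lower number (1.37 log units; beyond the scatter) from compound 1 to compound 3 and a 1.1-fold higher number (0.06 log units; within the scatter) from compound 2 to compound 4, at least 27-fold (1.43 log units) apart, beyond the scatter of two such steps Compound 1 gives > 100000 nM, which is a limit of the assay and not a number, so the step from it has a known floor but no known size: the limit of > 100000 nM in this assay, at which 1 of the 4 values shown sits. The two steps show that the outcome of this change depended on the core in this pair, but they do not show why, and two cores cannot say which outcome is the more usual in the series.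

The compounds shown leave open whether an acetyl group or a methyl group on that amine nitrogen would follow tert-butoxycarbonyl or hydrogen on each core. They also leave open whether a longer chain would alter the gap between the two steps.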